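Cytotoxicity notes on a cyclic sulfonate series

A few compounds are considered here, and "the series" means these few. Any claim that something is new, unique, unknown or untested is made for them only; others in the source may bear on it.

Compound 1 `CCC1(Cc2ccccc2)OS(=O)(=O)C=C1OCc1ccc(Cl)c(Cl)c1` — an ADME assay on HEL cells (Homo sapiens) for cytotoxicity, with a stated time of 3 days; a lower number here means that less compound is tolerated, a higher number that more compound is tolerated: >= 20000 nM
Compound 2 `CCC1(Cc2ccccc2)OS(=O)(=O)C=C1OCc1ccc(C)cc1` — this assay: >= 16000 nM

Both values are limits of the assay rather than numbers. For compound 1 the reading stops at the limit described in the limit of >= 20000 nM in this assay, at which 1 of the 2 values shown sits. For compound 2 the reading stops at the limit described in the limit of >= 16000 nM in this assay, at which 1 of the 2 values shown sits. Within the data shown here, the one measured step, a step that the two limits leave unreadable from compound 1 to compound 2, is therefore not readable in size or direction; it only shows that neither compound reached a cytotoxic concentration within the tested range. Compound 2 thus stands at a limit, with no numeric position on the scale.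

The next compound, compound 3 `CCC1(Cc2ccccc2)OS(=O)(=O)C=C1OCC#N`, differs from compound 2 by cyano in place of 4-methylphenyl on a saturated chain carbon bound to an oxygen on an unsaturated carbon. Among the measured compounds shown here, no measured step bears directly on this change; the only step available, the one from compound 1 to compound 2, is itself unreadable. The expectation is therefore that compound 3 again fails to reach a cytotoxic concentration, so that the step that the limit leaves unreadable from compound 2 to compound 3 is expected to lie within the scatter. Compound 3 is estimated at 20000 nM, in the range 8000 nM to 60000 nM.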

Compound 3, minimum cytotoxic concentration: > 400000 nM
Compound 3: no number, only a limit (the forecaster's own chance of this, stated with the estimate: 80%); at least 20-fold (1.30 log units) between middle value and limit.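

In this assay compound 3 gives > 400000 nM, a limit of the assay and not a number. Among these compounds, compound 1, compound 2 and compound 3 all stand at limits, and no step among them can be read in size or direction. The compounds shown leave open what concentration is cytotoxic for any of the three, and whether cyano in place of 4-methylphenyl changes it.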